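The compounds below may be only part of what the source reports. "The series", "measured", "known", "first", "only" and "open" are said of these compounds alone.

Compound 1, `O=C1C(Nc2ccccc2)=CC(=O)c2c1nc1n2[C@H]2OC[C@@H](O)[C@H]2OC1`, in a functional assay on HeLa cells (Homo sapiens) for inhibition, read by sulforhodamine B assay; on this read-out higher numbers stand for weaker inhibition and lower numbers for stronger inhibition: > 8000 nM, a limit of the assay rather than a number.
Compound 2, `O=C1C=C(N2CCC2)C(=O)c2c1nc1n2[C@H]2OC[C@@H](O)[C@H]2OC1`, in this assay: > 16000 nM, again a limit.
Compound 3, `O=C1C=C(NC2CCCCC2)C(=O)c2c1nc1n2[C@H]2OC[C@@H](O)[C@H]2OC1`, in this assay: > 16000 nM, again a limit.

Compound 1 therefore stands nowhere definite on the numbers shown: only a limit is known for it, and the two other values are limits as well. Two of the three sit at the limit of > 16000 nM in this assay, at which 2 of the 3 values shown sit, one at the limit of > 8000 nM in this assay, at which 1 of the 3 values shown sits. Going by the values given here, the single step between measured compounds that differ in one place, a step that the two limits leave unreadable from compound 2 to compound 3, concerns cyclohexylamino in place of azetidin-1-yl on a double-bonded ring carbon and cannot be read because both ends are limits.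

The step to compound 4, `COc1ccc(NC2=CC(=O)c3c(nc4n3[C@H]3OC[C@@H](O)[C@H]3OC4)C2=O)cc1`, changes the anilino group of compound 1: methoxy in place of hydrogen on an aromatic carbon. Among the compounds with values here, no measured step bears on this change, so no direction and no size beyond the scatter can be expected from the data. Compound 4 is estimated at 10000 nM, between 3000 nM and 30000 nM, and the expected step from a step that the limit leaves unreadable from compound 1 to compound 4 most likely ends again at a limit.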

Compound 4, half-maximal inhibitory concentration: > 8000 nM
Compound 4: a limit, no number; the forecaster's own chance of this, stated with the estimate: 80%; the middle value is on the limit's open side.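

The step between compound 1 and compound 4 cannot be read, since both ends are limits: the limit of > 8000 nM in this assay, at which 2 of the 4 values shown sit. The compounds shown leave open whether methoxy in place of hydrogen on an aromatic carbon alters inhibition in this assay and how these compounds rank against one another.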